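Aryl Exchange and Cytotoxicity: Working Notes on Four Compounds

This account rests on a few compounds, and the source may have more. Where it says the series, first, only, none or still open, it means among the compounds named here.

Compound 1 `Cc1cc(-c2ccsc2)c2ncc(CSCCc3ccccc3)n2c1` gives 100 ug/mL in an ADME assay on HEL cells (Homo sapiens) for cytotoxicity, with a stated time of 3 days; on this read-out lower numbers stand for higher toxicity in this test and higher numbers for lower toxicity in this test. Compound 3 `COc1ccc(-c2cc(C)cn3c(CSCCc4ccccc4)cnc23)cc1` gives 20 ug/mL in this assay. Going by the values given here, the one measured step, a 5.0-fold lower number from compound 1 to compound 3 (0.70 log units; beyond the scatter), shows that exchanging the aryl group on the shared core can shift the read-out beyond the scatter, though only modestly.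

Compound 2 `Cc1cc(-c2ccc(C#N)cc2)cn2c(CSCCc3ccccc3)cnc12` stands differently: in this assay compound 2 gives >= 20 ug/mL, which is a limit of the assay and not a number. This is the limit of >= 20 ug/mL in this assay, at which 1 of the 3 values shown sits, so compound 2 is known only as a bound.

Compound 4 `Cc1cc(-c2cccc(O)c2)cn2c(CSCCc3ccccc3)cnc12` differs from compound 2 by 3-hydroxyphenyl in place of 4-cyanophenyl on an aromatic carbon. Among the compounds with values here, no measured step covers this pair of aryl groups; the step of a 5.0-fold lower number from compound 1 to compound 3 (0.70 log units; beyond the scatter) bears on it only as a sign of how far an aryl exchange at this position has moved the number so far. A step of similar or smaller size is expected, in either direction, with none beyond the scatter the likeliest outcome. The expected change is a step that the limit leaves unreadable from compound 2 to compound 4. Compound 4 is expected to give 30 ug/mL in this assay, with a range of 12 ug/mL to 100 ug/mL.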

Compound 4, minimum cytotoxic concentration: 20 ug/mL
Compound 4: middle estimate off by 1.5-fold (0.18 log units), on the high side; low and high end bracket the measured number.
By their numbers in this assay, from the lowest: compounds 3 and 4 (each within the scatter of the next); then compound 1.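

Compound 2 gives >= 20 ug/mL, which is a limit of the assay and not a number. The exchange of 4-cyanophenyl for 3-hydroxyphenyl gives a number no higher from compound 2 to compound 4 (the limit leaves the size open), so it cannot be read as a step of any size: the limit of >= 20 ug/mL in this assay, at which 1 of the 4 values shown sits.

What compound 4 adds is a measured number for an aryl group carrying a hydrogen-bond donor at this position: in this assay compound 4 gives 20 ug/mL. Compound 3, with 4-methoxyphenyl, gives 20 ug/mL, within the scatter of compound 4, while compound 1, with thiophen-3-yl, gives 100 ug/mL.

As far as these compounds go, whether an amine or a carboxylic acid on the phenyl ring would move the number at this position stays open, as does how 4-hydroxyphenyl would compare with 3-hydroxyphenyl. The side chain is the same in all the compounds shown, so they say nothing about a longer chain there.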